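The source may hold more compounds than are shown below. What is called first, only, known or untested is meant among the compounds shown, and "the series" means these compounds.

Measured compounds:
compound 1 `O=C([C@@H]1C[C@H](N2CCN(c3nccn3-c3ccccc3)CC2)CN1)N1CCSC1` — 58%
compound 2 `O=C([C@@H]1C[C@H](N2CCN(c3nnnn3C3CCCCC3)CC2)CN1)N1CCSC1` — 10.5%
compound 3 `Cc1cc(N2CCN([C@@H]3CN[C@H](C(=O)N4CCSC4)C3)CC2)n(-c2ccc(F)cc2)n1` — "not determined" (no result reported)

In a functional assay on the whole organism (plasma, strain Wistar) for inhibition, with Rattus norvegicus as the target, read by fluorescence, with a stated time of 9 h, at a dose of 3 umol/kg by the oral route (a lower number here means less inhibition, a higher number more inhibition at the dose given (going by the name of the read-out)), compound 1 gives 58%. Compound 2, which carries a different five-membered ring on the piperazine of the shared core, gives 10.5% in the same assay. Going by the values given here, compound 3 stands without any number in this assay: its measurement was not determined, so there is no value of its own to set against the two measured compounds, and no step between it and either of them can be stated.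

Compound 4 `Cc1cc(N2CCN([C@@H]3CN[C@H](C(=O)N4CCSC4)C3)CC2)n(-c2cccnc2)n1` is the next compound to be measured. It differs from compound 3 in one place: pyridin-3-yl in place of 4-fluorophenyl on an aromatic nitrogen. No step between two measured compounds is available that would show how a change of this kind moves the read-out in this assay, and compound 3 itself has no value, so the size and direction of the step from compound 3 to compound 4 cannot be drawn from the data shown. The two measured compounds only mark the spread of values seen so far in this assay, from the result of compound 2 to that of compound 1.

On that basis compound 4 is expected to give about 35% in this assay, with an estimated range from 5% to 70%.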

Compound 4, a percentage reported as inhibition, in the whole organism at one dose (the size of the read-out at that dose, not a potency): 40.8%
Compound 4: the middle estimate sits 5.8 percentage points below what was measured, and the stated range covers the measured number.
By their numbers in this assay, from the lowest: compound 2; then compound 4; then compound 1.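

Going by these compounds alone, the result for compound 4 in this assay gives no new step, as compound 3 and compound 4 do not form a pair with two values to compare. The compounds shown leave open how pyridin-3-yl in place of 4-fluorophenyl moves this read-out. Nothing shown offers an explanation for the value of compound 4.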